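Small changes on a nitrogen, and a carboxylic acid to come

A few compounds are considered here, and "the series" means these few. Any claim that something is new, unique, unknown or untested is made for them only; others in the source may bear on it.

Compound 1 `COc1cc(OC)c(/C=C/S(=O)(=O)Cc2ccc(OC)c([N+](=O)[O-])c2)c(OC)c1`: 2500 nM
Compound 2 `COC(=O)CCNc1cc(CS(=O)(=O)/C=C/c2c(OC)cc(OC)cc2OC)ccc1OC`: 1000 nM
Compound 3 `COC(=O)C(Nc1cc(CS(=O)(=O)/C=C/c2c(OC)cc(OC)cc2OC)ccc1OC)c1ccc(F)cc1`: 800 nM

In a functional assay on K562 cells (Homo sapiens) for cytotoxicity, read by trypan blue exclusion, with a stated time of 96 h (a higher number here means a weaker inhibitor, a lower number a stronger inhibitor), compound 3 gives 800 nM, a value within the scatter of compound 2 and lower than that of compound 1. Compound 4 `COc1cc(OC)c(/C=C/S(=O)(=O)Cc2ccc(OC)c(N[C@@H](C)C(=O)O)c2)c(OC)c1` carries 1-carboxyethyl in place of (4-fluorophenyl)(methoxycarbonyl)methyl on a nitrogen on an aromatic ring. The closest evidence is an earlier swap on that nitrogen, a 1.3-fold lower number from compound 2 to compound 3 (0.10 log units; within the scatter). The other measured step, a 2.5-fold lower number from compound 1 to compound 2 (0.40 log units; beyond the scatter), was modest. Going by the values given here, no measured compound carries 1-carboxyethyl, so the uncertainty is wide. In this assay no step beyond the scatter is expected. The expected step is a 1.6-fold lower number from compound 3 to compound 4 (0.20 log units; within the scatter). For compound 4 the estimate is 500 nM, with an expected range from 60 nM to 2500 nM.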

Compound 4, half-maximal inhibitory concentration: 15 nM
Compound 4: middle estimate off by 33-fold (1.52 log units), on the high side, outside the stated range (below it).
By their numbers in this assay, from the lowest: compound 4; then compounds 3 and 2 (each within the scatter of the next); then compound 1.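

Putting 1-carboxyethyl on this nitrogen gives a 53-fold lower number from compound 3 to compound 4 (1.73 log units; beyond the scatter) in this assay and a 67-fold lower number from compound 2 to compound 4 (1.82 log units; beyond the scatter), whereas the earlier swap there stayed within the scatter, so this position can respond far more strongly than compounds 2 and 3 showed. Set against the nitro group, the step is a 170-fold lower number from compound 1 to compound 4 (2.22 log units; beyond the scatter). No available evidence accounts for this jump.

The compounds shown leave open whether the free carboxylic acid itself matters, a question that the methyl ester of 1-carboxyethyl or a 2-carboxyethyl group could address. From the compounds shown here alone, the opposite form of the defined stereocentre also remains open.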